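The source may report more compounds than this note shows. Statements on the series, on what has been measured and on what is new or still open speak of the compounds shown alone.

Measured compounds:
compound 1 `CC(CCCC(=O)O)c1cccc(OCc2ccc3ccccc3n2)c1`: 90 nM
compound 2 `CC(CCc1nnn[nH]1)Cc1ccc(OCc2ccc3ccccc3n2)cc1`: 12 nM
compound 3 `CC(CCC(=O)O)Cc1ccc(OCc2ccc3ccccc3n2)cc1`: 43 nM

The three compounds were examined in an assay on membranes from lung (Cavia porcellus) for binding affinity to cysteinyl leukotriene receptor (Homo sapiens); on this read-out lower numbers stand for stronger inhibition and higher numbers for weaker inhibition. In this assay compound 1 gives 90 nM, the highest of the three numbers, while compound 3 gives 43 nM and compound 2 gives 12 nM. Compound 1 and compound 3 share the same atoms joined differently; the difference between the two cores is not broken down here. Within the core of compound 3, the change 1H-tetrazol-5-yl in place of carboxy on a saturated chain carbon, four bonds along the chain from an aromatic carbon gave a 3.6-fold lower number from compound 3 to compound 2 (0.55 log units; beyond the scatter).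

Compound 4 `CC(CCCc1nnn[nH]1)c1cccc(OCc2ccc3ccccc3n2)c1` is not yet measured. It differs from compound 1 by 1H-tetrazol-5-yl in place of carboxy on a saturated chain carbon, four bonds along the chain from an aromatic carbon, which is the same change made from compound 3 to compound 2, at the same place. On that basis, compound 4 is expected to show a step from compound 1 close to the earlier one, estimated as a 3.6-fold lower number from compound 1 to compound 4 (0.56 log units; beyond the scatter), because compound 3 to compound 2 gave a 3.6-fold lower number from compound 3 to compound 2 (0.55 log units; beyond the scatter). For compound 4 the expected value is 25 nM, estimated to lie between 10 nM and 60 nM.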

Compound 4, inhibition constant: 31 nM
For compound 4 the middle estimate is 1.2-fold (0.09 log units) below the measured one; the range from low to high includes it.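

In this assay the exchange of carboxy for 1H-tetrazol-5-yl on the core of compound 1 gave a 2.9-fold lower number from compound 1 to compound 4 (0.46 log units; beyond the scatter) and so lowered the number on this core too. The step on this core matches the earlier one, and on these two cores the change carried over with much the same size: the same change on two cores in this assay, a 3.6-fold lower number (0.55 log units; beyond the scatter) from compound 3 to compound 2 and a 2.9-fold lower number (0.46 log units; beyond the scatter) from compound 1 to compound 4, 1.2-fold (0.09 log units) apart, within the scatter of two such steps. This agreement rests on just two pairs of compounds, and it does not show that the step would hold on any other core or why 1H-tetrazol-5-yl gives the lower number in either pair.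

The compounds shown leave open whether an acylsulfonamide or a hydroxamic acid in the same place on the chain would give a similar step, and whether the step would survive a longer chain. They also leave open which part of the difference between the two cores accounts for the gap between their carboxy compounds.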